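The source may hold more compounds than are shown below. What is called first, only, known or untested is meant among the compounds shown, and "the series" means these compounds.

Measured compounds:
compound 1, `CCOc1ccc(/C=N/NC(=O)COc2cccc3ccccc23)cc1O`, gives 18.1 ug/mL;
compound 2, `O=C(COc1cccc2ccccc12)N/N=C/c1ccc(O)cc1`, gives 60.6 ug/mL;
compound 3, `C/C(=N\NC(=O)COc1cccc2ccccc12)c1cccc([N+](=O)[O-])c1`, gives 10.5 ug/mL.

These three share one core and were tested in an ADME assay on HEL cells (Homo sapiens) for cytotoxicity; a higher number here means that more compound is tolerated, a lower number that less compound is tolerated. Among them, compound 2 stands highest: its number is well beyond the scatter above both compound 1 and compound 3, so it is the best tolerated of the three.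

Compound 4, `O=C(COc1cccc2ccccc12)N/N=C/c1ccccc1Br`, has not been measured. It differs from compound 2 in one place: 2-bromophenyl in place of 4-hydroxyphenyl on a carbon with a double bond to nitrogen. Among the compounds with values here, no measured pair shows this exact change, so the size of the step is uncertain. Since compound 2 holds the highest number and the other two compounds sit lower, the expected step is downward, beyond the scatter, as a 3.0-fold lower number from compound 2 to compound 4 (0.48 log units; beyond the scatter). For compound 4 the estimated value is 20 ug/mL, with a range from 8 ug/mL to 50 ug/mL.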

Compound 4, half-maximal cytotoxic concentration: 100 ug/mL
The estimate for compound 4 lay 5.0-fold (0.70 log units) below the measured number, and the stated range ends below it.
By their numbers in this assay, from the lowest: compounds 3 and 1 (each within the scatter of the next); then compounds 2 and 4 (each within the scatter of the next).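

In this assay, putting 2-bromophenyl in place of 4-hydroxyphenyl on a carbon with a double bond to nitrogen gives a 1.7-fold higher number from compound 2 to compound 4 (0.22 log units; within the scatter). This position therefore accepts a swap that removes the hydroxyl group, with its hydrogen-bond donor and acceptor, and adds a bromine, without a change that can be told from the scatter. No measurement at hand explains this result.

This single swap changes both the substituent and where it sits on the ring, so the two effects cannot be separated. On these data alone, whether a phenyl ring carrying an amine or a carboxylic acid would fit here equally well also remains open.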